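One Permeability Value and a Larger Group on the Carbonyl

The compounds below may be only part of what the source reports. "The series", "measured", "known", "first", "only" and "open" are said of these compounds alone.

Measured in an ADME assay on Caco-2 cells (Homo sapiens) for permeability, read by LC-MS, in the apical to basolateral direction, with a stated time of 2 h; on this read-out higher numbers stand for higher permeability and lower numbers for lower permeability:
compound 1 `COc1cc(C(=O)N2CCCC2)cc2nc(NCc3cccc(Cl)c3)oc12`: "not determined" (no result reported)
compound 2 `COc1cc(C(=O)N2CCCC2(C)C)cc2nc(NCc3cccc(Cl)c3)oc12`: "not determined" (no result reported)
compound 3 `COc1cc(C(=O)N2CC[C@@H](O)[C@H](C)C2)cc2nc(NCc3cccc(Cl)c3)oc12`: 126 nm/s

For the measured compounds named here, compound 3 holds the only actual number in this small set, so it cannot be ranked as high or low against its neighbours. Compound 1 and compound 2 share the core of compound 3 but offer no number for comparison.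

The next molecule is compound 4 `COc1cc(C(=O)N2CC(C)C(O)CC2CCO)cc2nc(NCc3cccc(Cl)c3)oc12`. It keeps the shared core and changes one group: 4-hydroxy-2-(2-hydroxyethyl)-5-methylpiperidin-1-yl in place of 4-hydroxy-3-methylpiperidin-1-yl on a carbonyl carbon. The entering group is the larger of the two and counts more hydrogen-bond donors.

Going by the values given here, no pair of measured compounds shows how a change at this place moves this assay, so the forecast rests on the structural change alone and carries a wide margin. Starting from compound 3 at 126 nm/s, a moderate fall is expected, though a result within the usual scatter would be no surprise. The expected size of the change is a 2.1-fold lower number from compound 3 to compound 4 (0.32 log units; beyond the scatter). The estimated value for compound 4 is 60 nm/s, within an expected range of 20 nm/s to 160 nm/s.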

Compound 4, apparent permeability: 9.4 nm/s
Compound 4: the middle estimate sits 6.4-fold (0.81 log units) above what was measured, outside the stated range (below it).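

In this assay, the group on this carbonyl carbon, whose other neighbour is an aromatic carbon, turns out to matter a great deal: putting 4-hydroxy-2-(2-hydroxyethyl)-5-methylpiperidin-1-yl in place of 4-hydroxy-3-methylpiperidin-1-yl gives a 13-fold lower number from compound 3 to compound 4 (1.13 log units; beyond the scatter). Until now the set held a single number and therefore no direction, whereas this first readable pair shows a large drop, well beyond the usual scatter, on moving to a larger group with more hydrogen-bond donors and acceptors. Still, this is one pair with several differences at once, and nothing measured here explains the drop or says which part of the new group goes with it.

Comparisons with compound 1 and compound 2 cannot be read, so it remains unknown how the smaller ring groups in those two compounds would compare at this position. Also open, going by these compounds, is whether a simple ethyl chain or a 2-aminoethyl chain in place of the 2-hydroxyethyl chain on the same ring would give a similarly low number or recover some of the value of compound 3.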